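The compounds below may be only part of what the source reports. "The series", "measured", "known", "first", "only" and "open" are said of these compounds alone.

Compound 2 `CS(=O)(=O)c1ccc(-n2c(=O)n(Cc3cc4cc(Cl)ccc4n3CCCC#N)c3cnccc32)cc1` is the reference here. In an ADME assay on HeLa cells (Homo sapiens) for cytotoxicity, read by ATP content, with a stated time of 3 days (a lower number here means that less compound is tolerated, a higher number that more compound is tolerated), compound 2 gives only the assay limit > 50000 nM. Compound 1 `N#CCCCn1c(Cn2c(=O)n(-c3ccncc3F)c3ccncc32)cc2cc(Cl)ccc21` likewise gives only the limit > 50000 nM in this assay. The step that the two limits leave unreadable from compound 1 to compound 2 is accordingly not readable. The measured picture is summed up by the limit of > 50000 nM in this assay, at which 2 of the 2 values shown sit. Compound 3 `N#CCCCn1c(Cn2c(=O)n(C3CC3)c3ccncc32)cc2cc(Cl)ccc21` differs from compound 2 by cyclopropyl in place of 4-(methylsulfonyl)phenyl on an aromatic nitrogen. Going by the values given here, no measured step bears on this change, and the step of a number no higher from compound 2 to compound 3 (the limit leaves the size open) is expected to stay within the scatter. Compound 3 is therefore estimated at 50000 nM, with a range from 20000 nM to 100000 nM.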

Compound 3, half-maximal cytotoxic concentration: > 50000 nM
Compound 3 was reported as a limit; the forecaster's own chance of this, stated with the estimate: 70%; the middle value lies on the limit itself.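

Compound 1, compound 2 and compound 3 all stand at a limit in this assay, so no step among them can be read: the limit of > 50000 nM in this assay, at which 3 of the 3 values shown sit.

The compounds shown leave open where the half-maximal cytotoxic concentration of each one actually lies, and whether the group on the aromatic nitrogen changes it at all.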